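The source may report more compounds than this note shows. Statements on the series, on what has been measured and on what is new or still open speak of the compounds shown alone.

Measured compounds in a functional assay on MCF7 cells (Homo sapiens) for antiproliferative activity, read by sulforhodamine B assay, with a stated time of 48 h; a higher number here means a weaker inhibitor of growth, a lower number a stronger inhibitor of growth:
- Compound 1 `COc1cc(Cn2cc(CNC(=O)c3cn(-c4ccccc4)nc3-c3ccccc3)nn2)cc(OC)c1OC`: compound 1 gives only a limit of the assay, > 100000 nM.
- Compound 2 `O=C(NCc1cn(Cc2ccc(F)cc2)nn1)c1cn(-c2ccccc2)nc1-c1ccc(F)cc1`: compound 2 gives 55300 nM.
- Compound 3 `COc1ccc(Cn2cc(CNC(=O)c3cn(-c4ccccc4)nc3-c3ccc(F)cc3)nn2)cc1OC`: compound 3 gives only a limit of the assay, > 100000 nM.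

Going by the values given here, compound 3 thus stands at the edge of what this assay reports, as does compound 1, while compound 2 is the one compound with a number. Among the compounds with values here, the one measured step, an at least 1.8-fold higher number from compound 2 to compound 3 (0.25 log units; that floor lies within the scatter), lies within the scatter. Compound 4 `COc1cc(Cn2cc(CNC(=O)c3cn(-c4ccccc4)nc3-c3ccc(F)cc3)nn2)cc(OC)c1OC` differs from compound 3 by methoxy in place of hydrogen on an aromatic carbon. Within the data shown here, that change is not matched by any measured step; the only guide is the limit of > 100000 nM in this assay, at which 2 of the 3 values shown sit. The expected outcome is a step of a number no higher from compound 3 to compound 4 (the limit leaves the size open), that is, none beyond the scatter, with compound 4 most likely again reaching only the limit. Compound 4 is therefore estimated at 100000 nM, between 40000 nM and 300000 nM.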

Compound 4, concentration for 50% growth inhibition: 4300 nM
Estimate against measurement, compound 4: 23-fold (1.37 log units) above; measured number outside the range, below it.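

The third methoxy group makes a large difference at this position: 3,4-dimethoxyphenyl becoming 3,4,5-trimethoxyphenyl gives an at least 23-fold lower number from compound 3 to compound 4 (1.36 log units; beyond the scatter). The 3,4,5-trimethoxyphenyl group also outperforms 4-fluorophenyl on the same chain carbon, with a 13-fold lower number from compound 2 to compound 4 (1.11 log units; beyond the scatter). The fluoro matters too, since with 3,4,5-trimethoxyphenyl kept, fluoro in place of hydrogen on an aromatic carbon gives an at least 23-fold lower number from compound 1 to compound 4 (1.36 log units; beyond the scatter).

Going by these compounds, whether a hydroxy, an ethoxy or an amine at this position would do the same remains open. The full size of the two steps that start from a limit also remains open: the limit of > 100000 nM in this assay, at which 2 of the 4 values shown sit.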